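The compounds below may be only part of what the source reports. "The series", "measured", "known", "first", "only" and "open" are said of these compounds alone.

Compound 1 `COc1ccc(Cl)cc1NC(=O)CN1CCN(S(=O)(=O)N2CCN(S(=O)(=O)c3ccccc3)CC2)CC1` was tested in an assay on HEK293 cells for inhibition of potassium channel subfamily T member 1 (Homo sapiens), read by thallium flux (on this read-out lower numbers stand for stronger inhibition and higher numbers for weaker inhibition), where compound 1 gives 1100 nM. Among the compounds with a numbered result, compound 1 holds the lower of the two numbers: compound 3 `COc1ccc(Cl)cc1NC(=O)N1CCCN(S(=O)(=O)N2CCC(C)CC2)CC1` gives 6200 nM in this assay, a gap that lies beyond the usual scatter. Compound 2 `COc1ccccc1NC(=O)CN1CCN(S(=O)(=O)N2CCC(C)CC2)CC1` sits at the limit of > 10000 nM in this assay, at which 1 of the 3 values shown sits. In this assay compound 2 is recorded as > 10000 nM, which is a limit of the assay and not a number. Among the measured compounds shown here, none of these three compounds differs from another in a single place, so no measured single step is available to lean on. Compound 4 `CCCC1CCN(C(=O)N2CCN(S(=O)(=O)N3CCN(CC(=O)Nc4cc(Cl)ccc4OC)CC3)CC2)CC1` has not yet been measured in this assay. It differs from compound 1 in one place: (4-propylpiperidin-1-yl)carbonyl in place of phenylsulfonyl on an amine nitrogen in a ring. From the compounds shown here alone, with no comparable change among the measured compounds, the direction of the step remains open. Compound 4 is expected to give roughly 2000 nM in this assay, within a range from 500 nM to 8000 nM. That estimate means an expected step of a 1.8-fold higher number from compound 1 to compound 4 (0.26 log units; within the scatter) that would not stand clearly beyond the scatter.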

Compound 4, half-maximal inhibitory concentration: > 10000 nM
Compound 4: only a limit was reported; the forecaster's own chance of this, stated with the estimate: 15%; middle value at least 5.0-fold (0.69 log units) from the limit.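

Among the compounds shown here, the step of an at least 9.0-fold higher number from compound 1 to compound 4 (0.95 log units; beyond the scatter) is the first measured single change in this set, and it is a clear loss of inhibition in this assay. It shows that this amine nitrogen in a ring does not tolerate every group: with phenylsulfonyl the compound keeps a measurable number, while with (4-propylpiperidin-1-yl)carbonyl it does not. The result for compound 4 is a limit of the assay and not a number, so the true size of the step stays unknown: the limit of > 10000 nM in this assay, at which 2 of the 4 values shown sit.

This change replaces the linking sulfonyl and the ring on it at the same time, so the compounds shown cannot say which of the two parts accounts for the loss. A benzoyl group or a methylsulfonyl group at the same nitrogen would pull those two parts apart.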